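Working notes: 2,6-dimethoxyphenyl on the sulfonyl-bound oxygen

The source may report more compounds than this note shows. Statements on the series, on what has been measured and on what is new or still open speak of the compounds shown alone.

Measured so far:
Compound 1, `CC(C)c1cccc(C(C)C)c1OC(=O)NS(=O)(=O)Oc1ccccc1`: in an assay on liver for inhibition of sterol O-acyltransferase 1 (Rattus norvegicus), using microsomes (on this read-out lower numbers stand for stronger inhibition and higher numbers for weaker inhibition), compound 1 gives only a limit, > 50000 nM.
Compound 2, `Cc1cccc(C)c1OS(=O)(=O)NC(=O)Oc1c(C(C)C)cccc1C(C)C`: in this assay compound 2 gives only a limit, > 50000 nM.

For the measured compounds named here, compound 2 therefore stands at the limit of this assay, with no number of its own; the one further value in the set is also a limit (the limit of > 50000 nM in this assay, at which 2 of the 2 values shown sit). Compound 3, `COc1cccc(OC)c1OS(=O)(=O)NC(=O)Oc1c(C(C)C)cccc1C(C)C`, differs from compound 2 in one place: 2,6-dimethoxyphenyl in place of 2,6-dimethylphenyl on an oxygen. Going by the values given here, the only measured step, a step that the two limits leave unreadable from compound 1 to compound 2, cannot be read in size or direction, since both of its ends sit at the limit (the limit of > 50000 nM in this assay, at which 2 of the 2 values shown sit). Among the compounds with values here, no measured step bears on the dimethoxy change itself, so no direction can be expected in this assay beyond the scatter, and a further limit is the likeliest outcome once compound 3 is measured. Compound 3 is expected to give about 60000 nM in this assay, within 10000 nM to 300000 nM. This estimate means an expected step that the limit leaves unreadable from compound 2 to compound 3.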

Compound 3, half-maximal inhibitory concentration: > 50000 nM
Compound 3 ended at the assay's limit (the forecaster's own chance of this, stated with the estimate: 85%); the middle value does not contradict the limit.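

Compound 3 sits at the limit in this assay, as do compound 1 and compound 2, so no step among the three can be read: the limit of > 50000 nM in this assay, at which 3 of the 3 values shown sit.

The compounds shown leave open how phenyl, 2,6-dimethylphenyl and 2,6-dimethoxyphenyl rank against one another, and whether any group on this oxygen gives a measurable inhibition.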